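Cytotoxicity notes on a pyrazole series in Huh-7 cells

The source may hold more compounds than are shown below. What is called first, only, known or untested is meant among the compounds shown, and "the series" means these compounds.

Measured so far:
compound 1 `Cc1ccccc1-c1nn(-c2cccc(Cl)c2)cc1CNCCN1CCN(C)CC1` — 16000 nM
compound 2 `Cc1ccccc1CNc1nn(-c2ccc(F)cc2F)cc1CNCCN1CCN(C)CC1` — > 20000 nM
compound 3 `Cc1ccccc1-c1nn(-c2ccc(F)cc2F)cc1CNC1CCN(S(C)(=O)=O)CC1` — > 20000 nM

In an ADME assay on Huh-7 cells (Homo sapiens) for cytotoxicity (on this read-out lower numbers stand for higher toxicity in this test and higher numbers for lower toxicity in this test), compound 1 gives 16000 nM. Compound 2 gives only a limit, > 20000 nM. Compound 3 likewise gives only a limit, > 20000 nM. For the measured compounds named here, compound 2 therefore stands at the limit of > 20000 nM in this assay, at which 2 of the 3 values shown sit, with no number of its own, so no measured step between it and any other compound can be read off.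

Compound 4 `CN1CCN(CCNCc2cn(-c3ccc(F)cc3F)nc2-c2ccc(OC(F)(F)F)cc2)CC1` is not yet measured. It differs from compound 2 in that (4-(trifluoromethoxy)phenyl in place of (2-methylbenzyl)amino on an aromatic carbon). With compound 1 sitting close to the limit and compounds 2 and 3 at it, a step from compound 2 to compound 4 of no more than the usual scatter is expected, towards or at the limit. Compound 4 is expected at 16000 nM, within 7000 nM to 30000 nM, giving an expected step of an at least 1.2-fold lower number from compound 2 to compound 4 (0.09 log units; that floor lies within the scatter).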

Compound 4, half-maximal cytotoxic concentration: 18000 nM
The estimate for compound 4 lay 1.1-fold (0.05 log units) below the measured number; measured number inside the range.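

At this position, in this assay, 4-(trifluoromethoxy)phenyl in place of (2-methylbenzyl)amino gives an at least 1.1-fold lower number from compound 2 to compound 4 (0.04 log units; that floor lies within the scatter). The swap drops the hydrogen-bond donor of the leaving group, and the read-out stays within the usual scatter at its floor. The full size of the step cannot be read because one end of it is only a limit: the limit of > 20000 nM in this assay, at which 2 of the 4 values shown sit.

Still open, from the compounds shown here alone, is how a carboxylic acid or a plain amine on this carbon would read. Also open, going by these compounds, is whether the same swap reads alike with a longer chain in place of the ((2-(4-methylpiperazin-1-yl)ethyl)amino)methyl group.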